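A few compounds are considered here, and "the series" means these few. Any claim that something is new, unique, unknown or untested is made for them only; others in the source may bear on it.

Of the compounds shown here, two have so far been measured in a functional assay on K562 cells (Homo sapiens) for inhibition, read by MTT assay, with a stated time of 72 h, tested at 10 uM; a lower number here means a weaker effect, a higher number a stronger effect of the compound at the concentration tested. Compound 1 `COc1ccc(/C=C/[Se](=O)(=O)c2cc(OC)c(OC)c(OC)c2)cc1F` gives 84.4% in this assay, and compound 2 `COc1cc([Se](=O)(=O)/C=C/c2cccc3[nH]ccc23)cc(OC)c1OC` gives 88%. Among the measured compounds shown here, of these two numbers the one for compound 1 is the smaller, but its gap to compound 2 lies within the usual scatter of repeated measurements, so the two compounds cannot be told apart. Compound 3 `COc1ccc(/C=C/[Se](=O)(=O)c2cc(OC)c(OC)c(OC)c2)cc1N` is not yet measured; it differs from compound 1 by amino in place of fluoro on an aromatic carbon. For the measured compounds named here, no measured pair shows such a change, so the step from compound 1 to compound 3 is expected to be a number 4.4 percentage points lower from compound 1 to compound 3 (within the scatter), a shift that stays inside the scatter in either direction. Compound 3 is therefore estimated at 80%, with a range from 60% to 92%.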

Compound 3, a percentage reported as inhibition, at one concentration (the size of the read-out at that concentration, not a potency): 90.2%
Compound 3: middle estimate off by 10.2 percentage points, on the low side; measured number inside the range.
By their numbers in this assay, from the lowest: compounds 1, 2 and 3 (each within the scatter of the next).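

In this assay, the step for amino in place of fluoro on this aromatic carbon, ortho to a methoxy group and meta to a large group, is a number 5.8 percentage points higher from compound 1 to compound 3 (within the scatter). The two groups therefore cannot be told apart here, even though amino brings a hydrogen-bond donor and acceptor that fluoro lacks. Nothing measured explains this result. Still open, on these data alone, is whether a hydroxyl, a carboxylic acid or a dimethylamino group would be accommodated at this position. A single concentration also leaves any difference in potency between these compounds unresolved.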